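Swapping Methoxy for Chloro on a Thiazinone Amide

The source may report more compounds than this note shows. Statements on the series, on what has been measured and on what is new or still open speak of the compounds shown alone.

Three measured compounds share one core and differ in the chain linking it to a methoxyphenyl group. In an assay on mitochondria (strain Sprague-Dawley) for inhibition of Amine oxidase [flavin-containing] B (Rattus norvegicus), read by fluorescence and Amplex Red, with stated times of 30 min and 45 min (on this read-out lower numbers stand for stronger inhibition and higher numbers for weaker inhibition), compound 1 `COc1cccc(CCC(=O)Nc2nc3ccccc3c(=O)s2)c1` gives 621 nM, compound 2 `COc1cccc(CCCC(=O)Nc2nc3ccccc3c(=O)s2)c1` gives 1300 nM, and compound 3 `COc1cccc(/C=C/CC(=O)Nc2nc3ccccc3c(=O)s2)c1` gives 2020 nM. Compound 3 stands above compound 1 by more than the usual scatter, while its number and that of compound 2 lie within the scatter of one another. Compound 4 `O=C(C/C=C/c1cccc(Cl)c1)Nc1nc2ccccc2c(=O)s1` differs from compound 3 by chloro in place of methoxy on an aromatic carbon. Going by the values given here, no measured pair shows this change, so the author expects no step beyond the scatter in this assay, estimated as a 1.1-fold lower number from compound 3 to compound 4 (0.05 log units; within the scatter). Compound 4 is therefore estimated at 1800 nM, within a range of 600 nM to 5500 nM.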

Compound 4, half-maximal inhibitory concentration: 840 nM
The estimate for compound 4 lay 2.1-fold (0.33 log units) above the measured number; measured number inside the range.
By their numbers in this assay, from the lowest: compounds 1, 4, 2 and 3 (each within the scatter of the next, the first and the last beyond it).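

Chloro in place of methoxy on this aromatic carbon gives a 2.4-fold lower number from compound 3 to compound 4 (0.38 log units; beyond the scatter), a step beyond the scatter in this assay. Going by these compounds alone, the earlier compounds differed only in the chain, so this is the first sign that the group on the aromatic ring also changes the number, at least on this unsaturated chain. Nothing at hand accounts for this step.

Going by these compounds, whether the same swap carries over to the chains of compound 1 and compound 2 remains open. So does how a fluoro, a methyl or an amine would read at this position.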